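The source may hold more compounds than are shown below. What is called first, only, known or untested is meant among the compounds shown, and "the series" means these compounds.

Compound 2, with the structure `COc1cncc(N2C[C@@H]3CCNC[C@@H]32)c1`, gives in a functional assay on HEK293 cells for agonist activity at Neuronal acetylcholine receptor; alpha3/beta4 (Homo sapiens), read by FLIPR (a higher number here means that more compound is needed for the effect, a lower number that less compound is needed), a value of 63500 nM. Among the compounds with values here, of the two compounds measured so far it stands at the higher number; compound 1, with the structure `N#Cc1cncc(N2C[C@H]3CCNC[C@H]32)c1`, gives in this assay a value of 5560 nM, and that gap lies beyond the usual scatter. Compound 3, with the structure `COc1cncc(N2C[C@H]3CCNC[C@H]32)c1`, is related to compound 2 by the following change: the two compounds have the same atoms and bonds and differ only in configuration as drawn: 2 of 2 stereo elements differ (all stereocentres are inverted: mirror images); a stereocentre at a saturated ring carbon is drawn S in compound 2 and R in compound 3; a stereocentre at a saturated ring carbon is drawn R in compound 2 and S in compound 3. The two compounds have the same atoms and bonds and differ only in configuration as drawn; a stereocentre at a saturated ring carbon is drawn S in compound 2 and R in compound 3, and a second stereocentre at a saturated ring carbon is drawn R in compound 2 and S in compound 3. Within the data shown here, no measured pair shows this inversion directly, so its effect is uncertain; since compound 3 shares its configuration with compound 1, which gives 5560 nM, a move toward a lower number is expected, a step of a 3.2-fold lower number from compound 2 to compound 3 (0.50 log units; beyond the scatter). Compound 3 is therefore estimated at 20000 nM, within a range from 5000 nM to 80000 nM.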

Compound 3, half-maximal effective concentration: 4360 nM
Compound 3: middle estimate off by 4.6-fold (0.66 log units), on the high side, outside the stated range (below it).
By their numbers in this assay, from the lowest: compounds 3 and 1 (each within the scatter of the next); then compound 2.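

Inverting both stereocentres gives a 15-fold lower number from compound 2 to compound 3 (1.16 log units; beyond the scatter) in this assay, so with the methoxy group held in place, configuration at these two saturated ring carbons matters on its own. The step can be assigned to stereochemistry alone because of this: the fact that compounds 2 and 3 differ only in the configuration as drawn. Within the configuration shared by compounds 1 and 3, the change of substituent, methoxy in place of cyano on an aromatic carbon, gives a 1.3-fold lower number from compound 1 to compound 3 (0.11 log units; within the scatter), so this read-out does not separate the two groups in that configuration.

The compounds shown leave open whether the same inversion would carry a step of similar size with a cyano group on the aromatic carbon. They also leave open how a chlorine atom, an amine or a longer ether such as ethoxy would compare at that carbon.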